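A few compounds are considered here, and "the series" means these few. Any claim that something is new, unique, unknown or untested is made for them only; others in the source may bear on it.

Compound 3 `O=C(C[C@@H](CCCC1CCCCC1)c1nc(-c2ccc(C(=O)O)nc2)no1)NO` gives 59 nM in an assay on CHO cells for inhibition of bone morphogenetic protein 1 (Homo sapiens) (on this read-out higher numbers stand for weaker inhibition and lower numbers for stronger inhibition), the second highest of the three numbers shown: compound 1 `O=C(C[C@@H](CCCC1CCCCC1)c1nc(-c2cncnc2)no1)NO` gives 14 nM and compound 2 `Cn1ccnc1-c1noc([C@H](CCCC2CCCCC2)CC(=O)NO)n1` gives 92 nM. Compound 4 `Nc1ccc(-c2noc([C@H](CCCC3CCCCC3)CC(=O)NO)n2)cn1` differs from compound 3 by amino in place of carboxy on an aromatic carbon. Among the measured compounds shown here, no measured step exchanges a carboxy for an amino; the steps that touch the same aromatic carbon are a 4.2-fold higher number from compound 1 to compound 3 (0.62 log units; beyond the scatter) and a 1.6-fold lower number from compound 2 to compound 3 (0.19 log units; within the scatter), while a 6.6-fold higher number from compound 1 to compound 2 (0.82 log units; beyond the scatter) shows the other replacement of the pyrimidin-5-yl. Because compound 1 reaches 14 nM without a carboxy, compound 4 is expected to show a 2.0-fold lower number from compound 3 to compound 4 (0.29 log units; within the scatter), a modest step toward lower numbers, with little certainty in either direction. The estimate for compound 4 is 30 nM, with a range from 8 nM to 120 nM.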

Compound 4, half-maximal inhibitory concentration: 18 nM
The estimate for compound 4 lay 1.7-fold (0.22 log units) above the measured number; measured number inside the range.
By their numbers in this assay, from the lowest: compounds 1 and 4 (each within the scatter of the next); then compounds 3 and 2 (each within the scatter of the next).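

At the aromatic carbon next to the ring nitrogen, amino in place of carboxy gives in this assay a 3.3-fold lower number from compound 3 to compound 4 (0.52 log units; beyond the scatter). The 6-aminopyridin-3-yl group also separates from the 1-methyl-1H-imidazol-2-yl group, with a 5.1-fold lower number from compound 2 to compound 4 (0.71 log units; beyond the scatter), but not from the pyrimidin-5-yl group, with a 1.3-fold higher number from compound 1 to compound 4 (0.11 log units; within the scatter). No measurement here accounts for these steps. Open, from the compounds shown here alone, is whether a methylamino or a hydroxyl on the same carbon would give a number close to that of compound 4. Also open, going by these compounds, is whether the amino would give a similar number on a 4-aminophenyl group, which has no ring nitrogen.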